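This account rests on a few compounds, and the source may have more. Where it says the series, first, only, none or still open, it means among the compounds named here.

In an ADME assay on BHK-21 cells (Mesocricetus auratus) for cytotoxicity, read by MTT assay, with a stated time of 96 h (on this read-out higher numbers stand for lower toxicity in this test and lower numbers for higher toxicity in this test), three compounds have been measured:

compound 1 `Clc1cccc(/N=N/N2CCCC2)c1`: > 100000 nM
compound 2 `c1ccc(/N=N/N2CCCCC2)cc1`: > 100000 nM
compound 3 `Clc1ccc(/N=N/N2CCCC2)cc1Cl`: 50000 nM

The value of compound 1 is a limit of this assay, not a number. The value of compound 2 is likewise a limit. Both sit at the limit of > 100000 nM in this assay, at which 2 of the 3 values shown sit. Compound 3 differs from compound 1 by chloro in place of hydrogen on an aromatic carbon, and this step gives an at least 2.0-fold lower number from compound 1 to compound 3 (0.30 log units; that floor lies within the scatter). The difference between the core of compound 1 and the core of compound 2 is not broken down here.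

Compound 4 `Clc1ccc(/N=N/N2CCCCC2)cc1` has not yet been measured in this assay. It differs from compound 2 by chloro in place of hydrogen on an aromatic carbon, the same kind of change as from compound 1 to compound 3, though not the same: in compound 3 the entering chloro is ortho to a chloro group and para to a group of 7 heavy atoms, while in compound 4 it is para to a group of 8 heavy atoms and no second chloro is part of the description.

Beside the measured step, a step of an at least 1.4-fold lower number from compound 2 to compound 4 (0.15 log units; that floor lies within the scatter) is expected, because the step of an at least 2.0-fold lower number from compound 1 to compound 3 (0.30 log units; that floor lies within the scatter) sits at a floor within the scatter. Compound 4 is estimated at 70000 nM, between 30000 nM and 150000 nM, and its value may again be reported only as a limit.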

Compound 4, half-maximal cytotoxic concentration: > 100000 nM
Compound 4 was reported as a limit (the forecaster's own chance of this, stated with the estimate: 50%); middle value at least 1.4-fold (0.15 log units) from the limit.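

Compound 4 gives > 100000 nM in this assay, which is a limit of the assay and not a number. Compound 2 also stands at a limit, so no step can be read between compound 2 and compound 4, and the values shown gather at one point: the limit of > 100000 nM in this assay, at which 3 of the 4 values shown sit.

The compounds shown leave open whether chloro in place of hydrogen changes the number of compound 2 at all.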